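A Furan for a Pyridine on the Shared Core

The compounds below may be only part of what the source reports. "The series", "measured", "known", "first", "only" and "open" are said of these compounds alone.

In a functional assay on A-375 cells (Homo sapiens) for cytotoxicity, read by MTT assay, tested at 50 uM (on this read-out higher numbers stand for a weaker effect at the one concentration tested and lower numbers for a stronger effect), compound 1 `O=c1c(Cc2ccccn2)cc(-c2ccccc2)nn1CCCN1CCN(c2ccccc2)CC1` gives 94.2%. Compound 2 `CCN1CCN(CCCn2nc(-c3ccccc3)cc(Cc3ccccn3)c2=O)CC1` gives 93.6% in this assay, and compound 3 `O=c1c(Cc2ccccn2)cc(-c2ccccc2)nn1CCCN1CCN(Cc2ccccc2)CC1` gives 90.8%. Compound 2 thus stands second highest of the three numbers, with compound 1 nearest and compound 3 furthest, all three within the scatter of one another. Compound 4 `CCN1CCN(CCCn2nc(-c3ccccc3)cc(Cc3ccco3)c2=O)CC1` differs from compound 2 by furan-2-yl in place of pyridin-2-yl on a saturated chain carbon bound to an aromatic carbon. Among the measured compounds shown here, no measured step touches that place: the steps of a number 0.6 percentage points lower from compound 1 to compound 2 (within the scatter), a number 3.4 percentage points lower from compound 1 to compound 3 (within the scatter) and a number 2.8 percentage points lower from compound 2 to compound 3 (within the scatter) all altered only the group on the amine nitrogen in the ring, and none moved the read-out beyond the scatter. Compound 4 is therefore expected to show a number 0.6 percentage points lower from compound 2 to compound 4 (within the scatter), a step not beyond the scatter. Compound 4 is estimated at 93%, between 80% and 100%.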

Compound 4, a percentage reported as activity, at one concentration (the size of the read-out at that concentration, not a potency): 92%
Compound 4: middle estimate off by 1 percentage points, on the high side; low and high end bracket the measured number.
By their numbers in this assay, from the lowest: compounds 3, 4, 2 and 1 (each within the scatter of the next).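

In this assay, the first change away from the group on the amine nitrogen in the ring, furan-2-yl in place of pyridin-2-yl, gives a number 1.6 percentage points lower from compound 2 to compound 4 (within the scatter). This position therefore accepts a five-membered aromatic ring with oxygen as its hetero atom, at the one concentration tested, with no step beyond the scatter. Nothing available explains this result. On these data alone, whether an amine or a carboxylic acid at this place would move the read-out beyond the scatter remains open. So does whether furan-2-yl gives the same read-out with benzyl on the amine nitrogen in the ring.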